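Methyl on the amine ring: an unmeasured epimer

This account rests on a few compounds, and the source may have more. Where it says the series, first, only, none or still open, it means among the compounds named here.

Compound 1, `CC1CCN(C[C@H](O)[C@]23CC[C@H](CC2=O)C3(C)C)CC1`: 158000 nM in an ADME assay on HEK-293T cells (Homo sapiens) for cytotoxicity, read by MTT assay, with a stated time of 72 h; on this read-out higher numbers stand for weaker inhibition and lower numbers for stronger inhibition
Compound 2, `CC1(C)[C@@H]2CC[C@@]1([C@@H](O)CN1CCCCC1)C(=O)C2`: 143000 nM in this assay
Compound 3, `CC1(C)[C@@H]2CC[C@@]1([C@H](O)CN1CCCCC1)C(=O)C2`: "not determined" (no result reported) in this assay

Compound 3 has no single number in this assay. It shares the core of compound 2, and the two differ only in the configuration as drawn (the fact that compounds 2 and 3 differ only in the configuration as drawn). Compound 4, `CC1CCN(C[C@@H](O)[C@]23CC[C@H](CC2=O)C3(C)C)CC1`, is the next step from compound 3: methyl in place of hydrogen on a saturated ring carbon. Among the compounds with values here, the one measured step that bears on this change is the reverse one, a 1.1-fold lower number from compound 1 to compound 2 (0.04 log units; within the scatter), which shows that removing the methyl from the ring carbon of the amine left the number where it stood. Going the other way, from compound 3 to compound 4, is therefore expected to produce no step beyond the scatter in this assay. Within the data shown here, since compound 3 has no number, the only anchor is the pair of values from compound 1 and compound 2, which sit together. For compound 4, the half-maximal inhibitory concentration in this assay is estimated at 150000 nM, with a range from 70000 nM to 320000 nM.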

Compound 4, half-maximal inhibitory concentration: 169000 nM
Compound 4: middle estimate off by 1.1-fold (0.05 log units), on the low side; the range from low to high includes it.
By their numbers in this assay, from the lowest: compounds 2, 1 and 4 (each within the scatter of the next).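

In this assay the new value gives a 1.1-fold higher number from compound 1 to compound 4 (0.03 log units; within the scatter). Within the data shown here, with methyl on the saturated ring carbon, drawing the stereocentre at the saturated chain carbon as S in place of R therefore leaves the number within the scatter, something the earlier compounds could not show while compound 3 had no number. This reading rests on a clean comparison of configuration alone: the fact that compounds 1 and 4 differ only in the configuration as drawn

On these data alone, the step from compound 3 to compound 4 cannot be read, so the effect of methyl in place of hydrogen with the chain carbon drawn S remains unknown. The compounds shown also leave open whether a longer chain such as ethyl, or a hydroxyl group, on that saturated ring carbon would keep the number in the same place.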